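The source may report more compounds than this note shows. Statements on the series, on what has been measured and on what is new or still open speak of the compounds shown alone.

In a functional assay on A549 cells (Homo sapiens) for cytotoxicity, read by MTT assay, with a stated time of 72 h (a lower number here means a stronger inhibitor, a higher number a weaker inhibitor), compound 2 (`CNC(=O)c1cc(Oc2ccc(C3=NNC(c4ccc(C#N)cc4)C3)cc2)ccn1`) stands at 17400 nM and compound 3 (`CNC(=O)c1cc(Oc2ccc(C3=NNC(c4ccc(Cl)c(Cl)c4)C3)cc2)ccn1`) at 10700 nM with the two values close (a 1.6-fold lower number from compound 2 to compound 3 (0.21 log units; within the scatter)), while compound 1 (`CNC(=O)c1cc(Oc2ccc(C3=NNC(c4cccc(Br)c4)C3)cc2)ccn1`) gives the clearly lower 2840 nM on this scale. Compound 4 (`CNC(=O)c1cc(Oc2ccc(C3=NNC(c4ccc(F)cc4)C3)cc2)ccn1`) carries fluoro in place of cyano on an aromatic carbon, para to a large group (fluoro in place of cyano on an aromatic carbon). For the measured compounds named here, no measured step makes this exact swap. The nearest guides are the other aryl changes, which are modest (a 6.1-fold higher number from compound 1 to compound 2 (0.79 log units; beyond the scatter); a 3.8-fold higher number from compound 1 to compound 3 (0.58 log units; beyond the scatter)) or small (a 1.6-fold lower number from compound 2 to compound 3 (0.21 log units; within the scatter)). A small shift toward a lower number is therefore expected in this assay, probably no more than the scatter (a 1.7-fold lower number from compound 2 to compound 4 (0.24 log units; within the scatter)). Compound 4 is estimated at 10000 nM (expected range 3500 nM to 25000 nM).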

Compound 4, half-maximal inhibitory concentration: 15100 nM
Beside the measured number, compound 4's estimate is 1.5-fold (0.18 log units) below it, and the stated range covers the measured number.
By their numbers in this assay, from the lowest: compound 1; then compounds 3, 4 and 2 (each within the scatter of the next).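

In this assay, fluoro in place of cyano on this aromatic carbon leaves the number within the scatter (a 1.2-fold lower number from compound 2 to compound 4 (0.06 log units; within the scatter)), so these two groups cannot be told apart here. Compound 4 is also not separated from the 3,4-dichlorophenyl compound (a 1.4-fold higher number from compound 3 to compound 4 (0.15 log units; within the scatter)), whereas the 3-bromophenyl compound remains apart (a 5.3-fold higher number from compound 1 to compound 4 (0.73 log units; beyond the scatter)). No evidence is available to explain these results. Going by these compounds, whether an amine or a carboxylic acid on this ring would move the number remains open, as does whether bromine at other ring positions would retain the lower number of compound 1.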